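Removing a Bromine Substituent: Expected Effect on Cytotoxicity

The compounds below may be only part of what the source reports. "The series", "measured", "known", "first", "only" and "open" are said of these compounds alone.

Of the compounds shown here, three have been measured in a functional assay on MCF7 cells (Homo sapiens) for cytotoxicity, read by MTT assay, with a stated time of 24 h; on this read-out lower numbers stand for stronger inhibition and higher numbers for weaker inhibition. Compound 1 `Cc1cc(O)c(C(=O)/C=C/c2ccccc2)c(-c2ccccc2)c1C(=O)/C=C/c1ccccc1` gives 10000 nM in this assay. Compound 2 `Cc1cc(O)c(C(=O)/C=C/c2ccccc2)c(-c2ccc(Br)cc2)c1C(=O)/C=C/c1ccccc1` gives 10000 nM. Compound 3 `Cc1cc(O)c(C(=O)/C=C/c2ccc(F)cc2)c(-c2ccc(Br)cc2)c1C(=O)/C=C/c1ccc(F)cc1` gives 20000 nM, the highest of the three numbers, although its gaps to compound 1 and to compound 2 both fall within the scatter of this assay. The difference between the core of compound 2 and the core of compound 3 is not broken down here. Compound 2 and compound 1 differ in a single place, (hydrogen in place of bromo on an aromatic carbon), and the measured step for this change is that no change at the digits printed from compound 2 to compound 1 (within the scatter). The unmeasured compound 4 `Cc1cc(O)c(C(=O)/C=C/c2ccc(F)cc2)c(-c2ccccc2)c1C(=O)/C=C/c1ccc(F)cc1` relates to compound 3 by the same change, (hydrogen in place of bromo on an aromatic carbon), at a place described in identical terms, so it is regarded as the same change. Since no change at the digits printed from compound 2 to compound 1 (within the scatter) for the same change, compound 4 is expected to move little, and the expected step is a 1.1-fold lower number from compound 3 to compound 4 (0.05 log units; within the scatter). The estimate for compound 4 in this assay is 18000 nM, with a range from 7000 nM to 45000 nM.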

Compound 4, half-maximal inhibitory concentration: 20000 nM
Estimate against measurement, compound 4: 1.1-fold (0.05 log units) below; the measured number falls inside the stated range.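

In this assay, putting hydrogen in place of bromo gives no change at the digits printed from compound 3 to compound 4 (within the scatter), and this step agrees with the earlier one on the other core: the same change on two cores in this assay, no change at the digits printed (within the scatter) from compound 2 to compound 1 and no change at the digits printed (within the scatter) from compound 3 to compound 4, 1.0-fold (0.00 log units) apart, within the scatter of two such steps Within these four compounds, then, the change from 4-bromophenyl to phenyl carries from one core to the other, with neither step beyond the scatter. This does not show that the result would hold on a further core or in a different assay, and with both steps within the scatter, a small effect of the change cannot be told apart from none.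

The compounds shown carry only bromo or hydrogen at this place, which leaves open what a chloro group, a methoxy group, an amine or a carboxylic acid would do there. On these data alone, it also remains open whether the read-out would respond to any such group on these cores.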